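The source may hold more compounds than are shown below. What is called first, only, known or untested is meant among the compounds shown, and "the series" means these compounds.

Within the data shown here, in an ADME assay on microsomes (Mus musculus) for metabolic stability (a lower number here means slower removal, a higher number faster removal of the compound), only two compounds have numbers so far. Compound 1 (`CNC(=O)[C@@H]1CCCN1S(=O)(=O)c1cccc(COc2cccc3c(C(F)(F)F)cc(C)nc23)c1`) gives 767 mL/min/kg and compound 2 (`Cc1cc(C(F)(F)F)c2cccc(OCc3c(Cl)ccc(S(=O)(=O)N4CCC[C@H]4C(N)=O)c3Cl)c2n1`) gives 12600 mL/min/kg as its clearance, which makes compound 2 the higher of the pair by a margin beyond the usual scatter. The two differ in more than one place, so no single change can be read from them. Compound 3 (`COC[C@@H]1CCCN1S(=O)(=O)c1ccc(Cl)c(COc2cccc3c(C(F)(F)F)cc(C)nc23)c1Cl`) matches compound 2 except on a saturated ring carbon next to the ring nitrogen, where methoxymethyl stands in place of carbamoyl (methoxymethyl in place of carbamoyl on a saturated ring carbon). Among the measured compounds shown here, no measured step shows what this swap does, so the starting point is simply the number of compound 2, 12600 mL/min/kg in this assay again. The expected step is a 1.1-fold higher number from compound 2 to compound 3 (0.05 log units; within the scatter) and it stays within the scatter, pointing slightly upward if anywhere. For compound 3 the estimated clearance is 14000 mL/min/kg with an expected range from 5000 mL/min/kg to 35000 mL/min/kg in this wide band.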

Compound 3, clearance: 1620 mL/min/kg
Compound 3: the middle estimate sits 8.6-fold (0.94 log units) above what was measured; measured number below the stated range.
By their numbers in this assay, from the lowest: compound 1; then compound 3; then compound 2.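

Among these compounds, on a saturated ring carbon next to the ring nitrogen, the group has a clear bearing on the read-out in this assay: methoxymethyl in place of carbamoyl gives a 7.8-fold lower number from compound 2 to compound 3 (0.89 log units; beyond the scatter), the first single change that can be read here. The swap keeps the count of heavy atoms and the single hydrogen-bond acceptor but leaves out the one hydrogen-bond donor, so a change this large can arise without any change in the number of heavy atoms. Nothing measured here explains why the number falls.

As far as these compounds go, whether the loss of the donor matters more than the change from carbonyl to ether remains open, as both happen in this one swap. A hydroxymethyl, a plain methyl or a carboxylic acid on the same carbon could help separate these features.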